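Notes on a selenium-bearing side chain

The source may hold more compounds than are shown below. What is called first, only, known or untested is meant among the compounds shown, and "the series" means these compounds.

In a functional assay on MDA-MB-231 cells (Homo sapiens) for antiproliferative activity, read by MTT assay, with a stated time of 48 h (on this read-out higher numbers stand for weaker inhibition and lower numbers for stronger inhibition), compound 1 (`COc1ccc(N(C)c2ccnc(Cl)n2)cc1`) gives 2820 nM. Compound 2 (`COc1ccc(N(C)c2ccnc(Cl)n2)cc1OCCCCCBr`) reads > 10000 nM, which is a limit of the assay. Compound 3 (`COc1ccc(N(C)c2ccnc(Cl)n2)cc1OCC[Se]C#N`) gives 2750 nM, level with compound 1 within the scatter.

Compound 4 (`COc1ccc(N(C)c2ccnc(Cl)n2)cc1OCCC[Se]C#N`) differs from compound 3 in one place, on a saturated chain carbon, two bonds along the chain from an oxygen on an aromatic ring: a group of 4 heavy atoms (2 carbon, 1 nitrogen, 1 selenium; no ring) in place of a group of 3 heavy atoms (1 carbon, 1 nitrogen, 1 selenium; no ring), on a saturated chain carbon, two bonds along the chain from an oxygen on an aromatic ring.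

Three measured steps stand nearby: an at least 3.5-fold higher number from compound 1 to compound 2 (0.54 log units; beyond the scatter), a 1.0-fold lower number from compound 1 to compound 3 (0.01 log units; within the scatter) and an at least 3.6-fold lower number from compound 2 to compound 3 (0.56 log units; beyond the scatter). None isolates this change. The last alters the chain and its end group together, so it offers only a loose guide. The closest reference is compound 3, whose side chain leaves the reading unmoved in a 1.0-fold lower number from compound 1 to compound 3 (0.01 log units; within the scatter), so no shift beyond the scatter is expected in this assay.

The expected step is a 1.1-fold lower number from compound 3 to compound 4 (0.04 log units; within the scatter). For compound 4 the estimated value is 2500 nM, with an expected range of 1000 nM to 6500 nM.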

Compound 4, half-maximal inhibitory concentration: 1490 nM
Beside the measured number, compound 4's estimate is 1.7-fold (0.22 log units) above it; low and high end bracket the measured number.
By their numbers in this assay, from the lowest: compounds 4, 3 and 1 (each within the scatter of the next). At a limit, above all of these: compound 2.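

In this assay, lengthening the selenium-bearing side chain at this place gives a 1.8-fold lower number from compound 3 to compound 4 (0.27 log units; within the scatter), and the full side chain gives a 1.9-fold lower number from compound 1 to compound 4 (0.28 log units; within the scatter), so a second chain length also stays level with the core of compound 1. Going by these compounds alone, the only step beyond the scatter is the one from the chain ending in bromine, an at least 6.7-fold lower number from compound 2 to compound 4 (0.82 log units; beyond the scatter), which shows that the selenium-bearing end group at this chain length also reads clear of the bromopentyl compound. Compound 2 stands at a limit of the assay, not at a number: the limit of > 10000 nM in this assay, at which 1 of the 4 values shown sits.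

From the compounds shown here alone, whether a longer chain ending in the same selenium group would move the reading beyond the scatter remains open. Also open, going by these compounds, is what the selenium atom itself contributes, which a matching chain ending in sulfur and nitrile, or in an amine or a carboxylic acid, would address.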